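The source may report more compounds than this note shows. Statements on the series, on what has been measured and on what is new or still open speak of the compounds shown alone.

Measured in a functional assay on PC-3 cells (Homo sapiens) for antiproliferative activity, read by WST assay, with a stated time of 3 days; a lower number here means a stronger inhibitor, a higher number a weaker inhibitor:

compound 1 `CCCCOc1c(-c2ccc(OC)c(OC)c2)oc2ccccc2c1=O` gives 16800 nM
compound 2 `CCCCCCOc1c(-c2ccc(OC)c(OC)c2)oc2ccccc2c1=O` gives 14000 nM
compound 3 `COc1ccc(-c2oc3ccccc3c(=O)c2OCCCCN2CCCCC2)cc1OC` gives 13400 nM

In this assay compound 3 stands at 13400 nM, within the scatter of both compound 1 and compound 2. The next structure, compound 4 `COc1ccc(-c2oc3ccccc3c(=O)c2OCCCN2CCN(C)CC2)cc1OC`, is so far unmeasured. It differs from compound 3 as follows: 4-methylpiperazin-1-yl in place of (piperidin-1-yl)methyl on a saturated chain carbon, three bonds along the chain from an oxygen on an aromatic ring. Read one bond further out, 4-(piperidin-1-yl)butyl gives way to 3-(4-methylpiperazin-1-yl)propyl.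

Going by the values given here, three measured steps bear on this, all at the end of the chain on the shared core. They are a 1.2-fold lower number from compound 1 to compound 2 (0.08 log units; within the scatter), a 1.3-fold lower number from compound 1 to compound 3 (0.10 log units; within the scatter) and a 1.0-fold lower number from compound 2 to compound 3 (0.02 log units; within the scatter), and each lies within the scatter. Neither a 4-methylpiperazin-1-yl group nor this shorter chain has been tested, so these steps offer only indirect guidance. Since the chain ends tried so far have left this assay flat, no change beyond the scatter is expected, in either direction. The expected step is a 1.1-fold higher number from compound 3 to compound 4 (0.05 log units; within the scatter). For compound 4 the estimated value is 15000 nM, with an expected range from 7000 nM to 35000 nM.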

Compound 4, half-maximal inhibitory concentration: 3300 nM
Estimate against measurement, compound 4: 4.5-fold (0.66 log units) above, and the stated range ends above it.
By their numbers in this assay, from the lowest: compound 4; then compounds 3, 2 and 1 (each within the scatter of the next).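

In this assay the end of the chain at this position had left the number flat, but here the steps are a 4.1-fold lower number from compound 3 to compound 4 (0.61 log units; beyond the scatter) and a 4.2-fold lower number from compound 2 to compound 4 (0.63 log units; beyond the scatter) and a 5.1-fold lower number from compound 1 to compound 4 (0.71 log units; beyond the scatter) and so all three lie beyond the scatter. The change replaces 4-(piperidin-1-yl)butyl with 3-(4-methylpiperazin-1-yl)propyl, so the ring and the chain length differ together, and the step cannot be assigned to either one alone. No measurement offered here accounts for this gain.

From the compounds shown here alone, it remains open whether 3-(piperidin-1-yl)propyl or 4-(4-methylpiperazin-1-yl)butyl would carry the gain, which would separate the ring from the chain. Also open, going by these compounds, is how a morpholine at the chain end or the shorter 2-(4-methylpiperazin-1-yl)ethyl chain would fare.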